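Diaryl ether benzylamines: extending the amine substituent

A few compounds are considered here, and "the series" means these few. Any claim that something is new, unique, unknown or untested is made for them only; others in the source may bear on it.

Compound 3 `CNCc1c(OC)cc(Oc2cccc(Nc3ccccc3)c2)cc1OC` stands at 15000 nM in a functional assay on SW-620 cells (Homo sapiens) for inhibition, read by MTT assay, with a stated time of 72 h (a higher number here means a weaker inhibitor, a lower number a stronger inhibitor), the higher of the two numbers given, though compound 2 `COc1ccc(CCCNCc2c(OC)cc(Oc3ccc(Nc4ccccc4)cc3)cc2OC)cc1` gives 14600 nM, within the scatter of it. Compound 1 `CCN1CCN(Cc2c(OC)cc(Oc3cccc(Nc4ccccc4)c3)cc2OC)CC1` returns only a limit of the assay, > 20000 nM. Among the compounds with values here, the one single-change step, an at least 1.3-fold lower number from compound 1 to compound 3 (0.12 log units; that floor lies within the scatter), rests on that limit and is itself within the scatter. Compound 4 `COc1ccc(CNCc2c(OC)cc(Oc3cccc(Nc4ccccc4)c3)cc2OC)cc1` differs from compound 3 by 4-methoxyphenyl in place of hydrogen on a saturated chain carbon bound to an amine nitrogen. Within the data shown here, no measured step bears on this change directly; compounds 2 and 3 differ in two places, and their values sit together. A step no larger than the scatter is therefore expected, a 1.3-fold lower number from compound 3 to compound 4 (0.10 log units; within the scatter). Compound 4 is estimated at 12000 nM, between 5000 nM and 30000 nM, with some chance that this assay reports only a limit.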

Compound 4, half-maximal inhibitory concentration: 6970 nM
Beside the measured number, compound 4's estimate is 1.7-fold (0.24 log units) above it; measured number inside the range.
By their numbers in this assay, from the lowest: compound 4; then compounds 2 and 3 (each within the scatter of the next). At a limit, above all of these: compound 1.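

On the saturated chain carbon bound to an amine nitrogen, 4-methoxyphenyl in place of hydrogen gives a step beyond the scatter in this assay, though a modest one: a 2.2-fold lower number from compound 3 to compound 4 (0.33 log units; beyond the scatter). Within the data shown here, this is the first single-change step to clear the scatter, so this position tolerates the larger group. The second step, an at least 2.8-fold lower number from compound 1 to compound 4 (0.45 log units; beyond the scatter), rests on a limit of the assay and not on a number: the limit of > 20000 nM in this assay, at which 1 of the 4 values shown sits.

On these data alone, whether the step belongs to the methoxy group or to the ring itself stays open. An unsubstituted benzyl on the same amine nitrogen, or a longer chain carrying the 4-methoxyphenyl, would separate the two.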